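This account rests on a few compounds, and the source may have more. Where it says the series, first, only, none or still open, it means among the compounds named here.

Values so far in an ADME assay on MT4 cells (Homo sapiens) for cytotoxicity, read by MTT assay, with a stated time of 5 days; a lower number here means that less compound is tolerated, a higher number that more compound is tolerated:
- compound 1 `Cc1cccc(C)c1Oc1cc(Nc2ccc(C#N)cc2)[nH]c(=O)c1Br` gives 63000 nM
- compound 2 `Cc1cc(C)cc(Oc2cc(Nc3ccc(C#N)cc3)[nH]c(=O)c2I)c1` gives 24000 nM
- compound 3 `Cc1cc(C)cc(Oc2cc(Nc3ccc(C#N)cc3)[nH]c(=O)c2)c1` gives 46000 nM

Compound 3 at 46000 nM lies within the scatter of both compound 1 and compound 2, so its place among the three numbers carries little weight.

The next compound is compound 4 `Cc1cc(C)cc(Oc2cc(Nc3ccc(C#N)cc3)[nH]c(=O)c2Br)c1`, and the change from compound 3 is bromo in place of hydrogen on an aromatic carbon which amounts to bromo in place of hydrogen on an aromatic carbon.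

Within the data shown here, one measured step bears directly on this carbon: a 1.9-fold higher number from compound 2 to compound 3 (0.28 log units; within the scatter) with iodo as the group that leaves. That step stays within the scatter. Among the measured compounds shown here, compound 1 also carries bromo and gives 63000 nM in this assay but its methyl groups are placed differently from those of compound 4, and no measured step links the two.

On this evidence, no change beyond the scatter is expected in this assay and no direction is firmly expected. The estimated step is a 1.2-fold lower number from compound 3 to compound 4 (0.08 log units; within the scatter) and it is expected to stay inside the scatter. For compound 4 the estimate is 38000 nM with an expected range from 17000 nM to 80000 nM as the likely span.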

Compound 4, half-maximal cytotoxic concentration: 19000 nM
Beside the measured number, compound 4's estimate is 2.0-fold (0.30 log units) above it; the range from low to high includes it.
By their numbers in this assay, from the lowest: compounds 4, 2, 3 and 1 (each within the scatter of the next, the first and the last beyond it).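

In this assay, this aromatic carbon, two atoms from the ring nitrogen, now gives a step beyond the scatter for bromo in place of hydrogen (a 2.4-fold lower number from compound 3 to compound 4 (0.38 log units; beyond the scatter)), whereas the earlier step between iodo and hydrogen stayed within it (a 1.9-fold higher number from compound 2 to compound 3 (0.28 log units; within the scatter)). Bromo and iodo at this carbon cannot be told apart (a 1.3-fold lower number from compound 2 to compound 4 (0.10 log units; within the scatter)), so the two halogens read as one level and the hydrogen compound is separated clearly from bromo alone. With bromo held in place, 3,5-dimethylphenyl in place of 2,6-dimethylphenyl on the oxygen also gives a step beyond the scatter (a 3.3-fold lower number from compound 1 to compound 4 (0.52 log units; beyond the scatter)), so the placing of the methyl groups counts in this assay as well as the group on this carbon.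

It remains open whether the bromo step holds with 2,6-dimethylphenyl on the oxygen, and whether a chloro, methyl or amino group at this carbon would fall with the halogens shown or with hydrogen. No measurement at hand accounts for either step beyond the scatter.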